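Removing one methyl from a flavone: what changes in cytotoxicity

This account rests on a few compounds, and the source may have more. Where it says the series, first, only, none or still open, it means among the compounds named here.

Measured compounds:
- compound 1, `COc1cc(C)cc2c1OC(c1ccccc1)CC2=O`: 26 ug/mL
- compound 2, `COc1ccc(-c2cc(=O)c3cc(OC)c(OC)c(OC)c3o2)cc1`: 5 ug/mL

In a functional assay on KB cells (Homo sapiens) for cytotoxicity (a lower number here means that less compound is needed, a higher number that more compound is needed for the effect), compound 2 gives 5 ug/mL, the lowest of the two numbers shown. Compound 1 gives 26 ug/mL in this assay, a higher number that lies beyond the scatter; the two compounds differ in several places at once, so their gap cannot be tied to one change.

Compound 3, `COc1cc2c(=O)cc(-c3ccc(O)cc3)oc2c(OC)c1OC`, has not been measured. It differs from compound 2 in one place: hydrogen in place of methyl on an oxygen on an aromatic ring. The methoxy on the 4-methoxyphenyl becomes a hydroxy, which adds a hydrogen-bond donor on the outer ring.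

For the measured compounds named here, no step between measured compounds isolates this change, so the expectation rests on compound 2 alone. For compound 3 the number in this assay is estimated to stay close to that of compound 2, with the step of a 1.2-fold higher number from compound 2 to compound 3 (0.08 log units; within the scatter) expected to lie within the scatter.

Compound 3 is estimated at 6 ug/mL, in a range of 2 ug/mL to 18 ug/mL.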

Compound 3, concentration for half-maximal effect: 0.7 ug/mL
For compound 3 the middle estimate is 8.6-fold (0.93 log units) above the measured one; the measured number lies below the stated range.
By their numbers in this assay, from the lowest: compound 3; then compound 2; then compound 1.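

For the compounds shown here, replacing the methoxy with a hydroxy on the 4-methoxyphenyl is the first change here that can be read on its own, and in this assay it gives a 7.1-fold lower number from compound 2 to compound 3 (0.85 log units; beyond the scatter), a step beyond the scatter. This shows that the position on the outer ring is not indifferent: one methyl on that oxygen separates the two numbers, and less compound is needed for the effect when a hydrogen stands in its place. Nothing available here gives a measured reason for this step.

The compounds shown leave open whether the step belongs to the hydroxy itself or to the loss of the methyl, which an amine at the same place or a longer chain such as ethoxy on the oxygen could help separate. They also leave open whether the same change on the methoxy groups of the shared core would give a step of similar size.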